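A few compounds are considered here, and "the series" means these few. Any claim that something is new, unique, unknown or untested is made for them only; others in the source may bear on it.

Working notes on the series. Two members are measured in a functional assay on CHO cells for agonist activity at Orexin receptor type 2 (Homo sapiens); a higher number here means that more compound is needed for the effect, a lower number that less compound is needed. Compound 1 `COc1cccc(C(=O)N(C)c2cccc3ccc(NS(=O)(=O)c4cc(-c5cccc(C(=O)N(C)C)c5)ccc4OC)cc23)c1` gives 22.7 nM in this assay. Compound 2 `COc1cccc(C(=O)Nc2c(C)ccc3ccc(NS(=O)(=O)c4cc(-c5cccc(C(=O)N(C)C)c5)ccc4OC)cc23)c1` gives 9.21 nM in this assay, the lowest of the two numbers; the distance from compound 1 to compound 2 lies beyond the scatter, and the two differ in more than one place, so only the two values themselves can be compared. Compound 3 `COc1cccc(C(=O)N(C)c2c(C)ccc3ccc(NS(=O)(=O)c4cc(-c5cccc(C(=O)N(C)C)c5)ccc4OC)cc23)c1` is not yet measured. The change from compound 2 to compound 3 is methyl in place of hydrogen on an amide-type nitrogen. Within the data shown here, no single-point step between measured members exists to calibrate it, so the expectation rests on the values alone: compound 1, which also carries the methyl on the amide-type nitrogen, gives 22.7 nM, and no large movement in either direction is expected. Compound 3 is expected to show a step of a 1.4-fold higher number from compound 2 to compound 3 (0.15 log units; within the scatter) in this assay, within or near the scatter. The estimate for compound 3 is 13 nM, in the range 4 nM to 40 nM.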

Compound 3, half-maximal effective concentration: 31.1 nM
Compound 3: middle estimate off by 2.4-fold (0.38 log units), on the low side; measured number inside the range.
By their numbers in this assay, from the lowest: compound 2; then compounds 1 and 3 (each within the scatter of the next).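

Among these compounds, the methyl on the amide-type nitrogen gives the first single-place reading at this position in this assay, and it is a modest one (a 3.4-fold higher number from compound 2 to compound 3 (0.53 log units; beyond the scatter)), so in the presence of the methyl on the aromatic carbon, the amide hydrogen and methyl are distinguishable here. The other single-place reading concerns the methyl on the aromatic carbon with the methyl on the amide-type nitrogen already in place, and this step stays within the scatter (a 1.4-fold higher number from compound 1 to compound 3 (0.14 log units; within the scatter)). No measurement bears on why the amide-type nitrogen responds to this change.

Among the compounds shown here, whether the step on the amide-type nitrogen holds without the methyl on the aromatic carbon remains open, as no compound here carries the amide hydrogen without that methyl. Also open, on these data alone, is how a longer chain such as ethyl, or an amine-bearing chain, on this nitrogen would read.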